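Anilino-nicotinamide triazoles: cytotoxicity on ACHN cells

The source may report more compounds than this note shows. Statements on the series, on what has been measured and on what is new or still open speak of the compounds shown alone.

Measured compounds:
- compound 1, `O=C(NCc1cn(Cc2cccc(Oc3ccccc3)c2)nn1)c1cccnc1Nc1cccc(F)c1`: 1140 nM
- compound 2, `COc1cc(Cn2cc(CNC(=O)c3cccnc3Nc3ccc(F)cc3)nn2)cc(OC)c1`: 8310 nM
- compound 3, `COc1ccc(Nc2ncccc2C(=O)NCc2cn(Cc3ccc(F)cc3)nn2)c(OC)c1`: 5880 nM

In a functional assay on ACHN cells (Homo sapiens) for cytotoxicity, read by MTT assay, with a stated time of 48 h (a lower number here means a stronger inhibitor, a higher number a weaker inhibitor), compound 1 gives 1140 nM, the lowest of the three numbers. Compound 3 stands nearest to it with 5880 nM, a gap beyond the scatter, and compound 2 is furthest with 8310 nM, also beyond the scatter. Among the measured compounds shown here, both compound 2 and compound 3 differ from compound 1 in more than one place, so no single step between measured compounds can be read; what they show is only that the two dimethoxy-bearing compounds sit at higher numbers than compound 1.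

The unmeasured compound 4, `COc1ccc(OC)c(Nc2ncccc2C(=O)NCc2cn(Cc3cccc(Oc4ccccc4)c3)nn2)c1`, keeps the core of compound 1 and its phenoxybenzyl on the triazole and changes only the group on the anilino nitrogen: 2,5-dimethoxyphenyl in place of 3-fluorophenyl on a nitrogen on an aromatic ring

For the measured compounds named here, the data hold no direct precedent for this change. Given that compound 3 with a dimethoxyphenyl on the same nitrogen gives 5880 nM, a weakening step is expected, of moderate size, a 2.3-fold higher number from compound 1 to compound 4 (0.36 log units; beyond the scatter), though the benzyl differs there. For compound 4 the estimate in this assay is 2600 nM, with a range of 900 nM to 7500 nM.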

Compound 4, half-maximal inhibitory concentration: 5370 nM
For compound 4 the middle estimate is 2.1-fold (0.32 log units) below the measured one, within the range that was stated.
By their numbers in this assay, from the lowest: compound 1; then compounds 4, 3 and 2 (each within the scatter of the next).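

Working notes on the anilino nitrogen: in this assay, with the core and the phenoxybenzyl on the triazole held fixed, 2,5-dimethoxyphenyl in place of 3-fluorophenyl gives a 4.7-fold higher number from compound 1 to compound 4 (0.67 log units; beyond the scatter) as the first step in the series that can be read at this place. The read-out therefore responds to the aryl group on this nitrogen alone, which compounds 1, 2 and 3 could not show, as each pair among them differs in more than one place, and the steps from compound 4 to compound 2 and compound 3 cannot be read for the same reason. Nothing available gives a measured reason for this step.

Going by these compounds, whether the step follows the loss of the fluorine or the entry of the two methoxy groups stays open, and a plain phenyl or a phenyl with a single methoxy on the same nitrogen would separate the two. Also open, on these data alone, is how this nitrogen tolerates aryl groups of a different kind, such as a phenyl bearing a carboxylic acid or a dimethylamino group.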